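Cytotoxicity notes: trimming the 4-fluorobenzyl on the amide nitrogen

A few compounds are considered here, and "the series" means these few. Any claim that something is new, unique, unknown or untested is made for them only; others in the source may bear on it.

Compound 1 `COC(=O)C[C@H](NC(=O)OC(C)(C)C)C(=O)N(Cc1ccc(F)cc1)C1(C(=O)NCc2ccccc2)CCN(Cc2ccccc2)CC1`: > 100000 nM
Compound 2 `COC(=O)C[C@H](NC(=O)OC(C)(C)C)C(=O)N(Cc1ccc(F)cc1)C1(C(=O)NCc2ccccc2)CCNCC1`: 100000 nM

In an ADME assay on MDCK cells (Canis lupus familiaris) for cytotoxicity, read by microscopy, with a stated time of 72 h (on this read-out higher numbers stand for lower toxicity in this test and lower numbers for higher toxicity in this test), compound 1 gives > 100000 nM, a limit of the test rather than a number. Compound 2 gives 100000 nM. The step of a number no higher from compound 1 to compound 2 (the limit leaves the size open) is thus of unreadable size, and the limit of > 100000 nM in this assay, at which 1 of the 2 values shown sits, keeps compound 1 at the ceiling. Compound 3 `COC(=O)C[C@H](NC(=O)OC(C)(C)C)C(=O)N(C)C1(C(=O)NCc2ccccc2)CCN(Cc2ccccc2)CC1` differs from compound 1 by hydrogen in place of 4-fluorophenyl on a saturated chain carbon bound to an amide-type nitrogen; cut one bond further out this reads 4-fluorobenzyl to methyl. For the measured compounds named here, no measured step touches this group, and the one known step, hydrogen in place of benzyl on an amine nitrogen in a ring, was unreadable. Compound 3 is therefore expected near the ceiling, at 100000 nM (range 50000 nM to 200000 nM). The step of a number no higher from compound 1 to compound 3 (the limit leaves the size open) is expected to stay within the scatter.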

Compound 3, minimum cytotoxic concentration: 20000 nM
Beside the measured number, compound 3's estimate is 5.0-fold (0.70 log units) above it; the whole stated range lies above it.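

In this assay the change of 4-fluorobenzyl to methyl gives an at least 5.0-fold lower number from compound 1 to compound 3 (0.69 log units; beyond the scatter). Unlike the step at the amine nitrogen in a ring, which cannot be read, this one shows that the position on the amide-type nitrogen can move the read-out, with the methyl compound the more toxic in this test. Compound 1 stands at a limit of the test, not a number, so the step has only a lower bound: the limit of > 100000 nM in this assay, at which 1 of the 3 values shown sits.

Going by these compounds, whether the fluorine or the whole 4-fluorophenyl carries the difference remains open. On these data alone, how an unsubstituted benzyl, a longer alkyl chain or a carboxylic acid would read at this nitrogen also remains open.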